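Shortening the alcohol side chain in a thromboxane receptor antagonist

The compounds below may be only part of what the source reports. "The series", "measured", "known", "first", "only" and "open" are said of these compounds alone.

Of the compounds shown here, two of a shared core have been measured in a functional assay on blood for antagonist activity at thromboxane A2 receptor (Homo sapiens); on this read-out lower numbers stand for tighter binding and higher numbers for weaker binding. Compound 1, with structure `O=C(O)CC/C=C\CO[C@H]1C(OCc2ccc(-c3ccccc3CCO)cc2)CC[C@@H]1N1CCCCCC1`, gives 2 nM and has the lowest number of the two. Compound 2, with structure `O=C(O)CC/C=C\CO[C@H]1[C@H](OCc2ccc(-c3ccccc3CO)cc2)CC[C@@H]1N1CCCCCC1`, gives 6.31 nM in this assay, a weaker result that lies beyond the usual scatter. Compound 3, with structure `O=C(O)CC/C=C\CO[C@H]1C(OCc2ccc(-c3ccccc3O)cc2)CC[C@@H]1N1CCCCCC1`, has not yet been measured. It differs from compound 1 in one place: hydroxy in place of 2-hydroxyethyl on an aromatic carbon, a change that keeps the hydrogen-bond donor and acceptor but removes the two-carbon link to the ring. Among the measured compounds shown here, with no measured pair showing exactly this change, the expectation for compound 3 rests only on the weaker result of compound 2 6.31 nM, which points towards a moderate loss. Compound 3 is therefore expected to give 8 nM, within a range of 3 nM to 25 nM, an estimated step of a 4.0-fold higher number from compound 1 to compound 3 (0.60 log units; beyond the scatter).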

Compound 3, dissociation constant: 15.9 nM
Compound 3: middle estimate off by 2.0-fold (0.30 log units), on the low side; the range from low to high includes it.
By their numbers in this assay, from the lowest: compound 1; then compound 2; then compound 3.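

Among the compounds shown here, putting hydroxy in place of 2-hydroxyethyl gives the first pair at this position that differs in one place only, and in this assay the change brings an 8.0-fold higher number from compound 1 to compound 3 (0.90 log units; beyond the scatter). Both groups count one hydrogen-bond donor and one hydrogen-bond acceptor, so keeping those counts is not enough on its own to preserve the number of compound 1. The group can still be cut back to a single oxygen without losing activity altogether, since compound 3 gives 15.9 nM.

Nothing shown here explains why the number rises with this change. Going by these compounds, it also remains open how a methoxy group, an amine or a carboxylic acid on this aromatic carbon would compare, or a longer chain such as 3-hydroxypropyl.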